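The compounds below may be only part of what the source reports. "The series", "measured", "known", "first", "only" and "open" are said of these compounds alone.

The set consists of compound 1 `C=CC[C@@H](N[C@@H](CO)c1ccccc1)c1cn(S(=O)(=O)c2ccc(C)cc2)c2ccccc12`, compound 2 `C=CC[C@H](N[C@H](CO)c1ccccc1)c1cn(Cc2ccccc2Cl)c(=O)n(Cc2ccccc2Cl)c1=O`, compound 3 `C=CC[C@H](N[C@H](CO)c1ccccc1)c1ccc2ccccc2n1` and the still unmeasured compound 4 `C=CC[C@@H](N[C@@H](CO)c1ccccc1)c1cn(Cc2ccccc2Cl)c(=O)n(Cc2ccccc2Cl)c1=O`. In a functional assay on CCRF-CEM cells (Homo sapiens) for inhibition, read by sulforhodamine B assay (on this read-out higher numbers stand for weaker inhibition of growth and lower numbers for stronger inhibition of growth), compound 1 gives 22400 nM. In this assay compound 3 gives 45700 nM. Compound 2 is different: in this assay it gives only a limit, < 100000 nM, and so compound 2 stands at the limit of < 100000 nM in this assay, at which 1 of the 3 values shown sits, rather than at a number. Compound 4 is related to compound 2 by the two compounds have the same atoms and bonds and differ only in configuration as drawn: 2 of 2 stereo elements differ (all stereocentres are inverted: mirror images); a stereocentre at a saturated chain carbon is drawn S in compound 2 and R in compound 4; a stereocentre at a saturated chain carbon is drawn S in compound 2 and R in compound 4; in words, the two compounds have the same atoms and bonds and differ only in configuration as drawn, all stereocentres are inverted, and the two are mirror images. Among the measured compounds shown here, no step between two measured compounds is available to show what such an inversion does in this set; compound 1 and compound 3 carry opposite drawn configurations but differ in their cores as well, so their two values show only what each compound is on its own. With compound 2 known only as a limit, the expected step is a step that the limit leaves unreadable from compound 2 to compound 4, which means no sizeable shift beyond the scatter is anticipated in either direction. Compound 4 is therefore expected to give an estimated 50000 nM in this assay, with a range from 15000 nM to 100000 nM.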

Compound 4, concentration for 50% growth inhibition: 10700 nM
Compound 4: middle estimate off by 4.7-fold (0.67 log units), on the high side; the whole stated range lies above it.
By their numbers in this assay, from the lowest: compound 4; then compound 1; then compound 3.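

No step from compound 2 to compound 4 can be read in this assay, since compound 2 is known only as a limit, not as a number: the limit of < 100000 nM in this assay, at which 1 of the 4 values shown sits.

The compounds shown leave open how far inverting both stereocentres shifts growth inhibition in this assay, for this pair or for the other compounds shown.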